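This account rests on a few compounds, and the source may have more. Where it says the series, first, only, none or still open, it means among the compounds named here.

Three compounds have been measured in a functional assay on MCF7 cells (Homo sapiens) for antiproliferative activity, read by MTT assay, with a stated time of 48 h; on this read-out higher numbers stand for weaker inhibition and lower numbers for stronger inhibition:

compound 1 `c1ccc(-c2nn(-c3ccccc3)cc2-c2nc3ccccc3[nH]2)cc1`, 3190 nM
compound 2 `Clc1ccc2[nH]c(-c3cn(-c4ccccc4)nc3-c3ccccc3)nc2c1`, 1960 nM
compound 3 `Fc1ccc(-c2nn(-c3ccccc3)cc2-c2nc3cc(Cl)ccc3[nH]2)cc1`, 2230 nM

Compound 2 arises from compound 1 by chloro in place of hydrogen on an aromatic carbon, and that change gave a 1.6-fold lower number from compound 1 to compound 2 (0.21 log units; within the scatter). Compound 3 carries the same chloro group on its core as compound 2; how the cores of compound 1 and compound 3 differ is not broken down here. Compound 4 `Fc1ccc(-c2nn(-c3ccccc3)cc2-c2nc3cc(Cl)c(Cl)cc3[nH]2)cc1` is not yet measured. It arises from compound 3 by chloro in place of hydrogen on an aromatic carbon; the entering chloro here sits ortho to a chloro group, which the change from compound 1 to compound 2 did not, so it is the same kind of change rather than the same one. Because the earlier step was a 1.6-fold lower number from compound 1 to compound 2 (0.21 log units; within the scatter), a similar small step, a 1.4-fold lower number from compound 3 to compound 4 (0.14 log units; within the scatter), is expected for compound 4. Compound 4 is estimated at 1600 nM, between 700 nM and 3600 nM.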

Compound 4, half-maximal inhibitory concentration: 6930 nM
For compound 4 the middle estimate is 4.3-fold (0.64 log units) below the measured one, outside the stated range (above it).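

In this assay the chloro entering on the core of compound 3 gave a 3.1-fold higher number from compound 3 to compound 4 (0.49 log units; beyond the scatter), so the earlier result did not carry over to this core: the same change on two cores in this assay, a 1.6-fold lower number (0.21 log units; within the scatter) from compound 1 to compound 2 and a 3.1-fold higher number (0.49 log units; beyond the scatter) from compound 3 to compound 4, 5.1-fold (0.70 log units) apart, beyond the scatter of two such steps. This step also puts the entering chloro ortho to a chloro group, which the step to compound 2 did not do, and two steps cannot separate that difference from the other differences between the cores. The result therefore shows that this change cannot be assumed to transfer within the series, but it does not show what sets the outcome.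

Left open is whether a fluoro, a methoxy group or an amine entering at the same place on the core of compound 3 would follow the chloro in this assay. Also open, going by these compounds, is whether the same change would again give a higher number on cores beyond these.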